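A few compounds are considered here, and "the series" means these few. Any claim that something is new, unique, unknown or untested is made for them only; others in the source may bear on it.

Measured so far in a functional assay on HCT-116 cells (Homo sapiens) for antiproliferative activity; a higher number here means a weaker inhibitor, a lower number a stronger inhibitor:

compound 1 `Cc1c2c(n3c1CCN(C(=O)[C@H](C)N)CC[C@H](C)Nc1cc-3ccc1C(N)=O)CC(C)(C)CC2=O`: 314 nM
compound 2 `Cc1c2c(n3c1CCNC[C@@H](C)[C@H](C)Nc1cc-3ccc1C(N)=O)CC(C)(C)CC2=O`: 24 nM

Of these two, compound 2 has the lower number, which marks it as the stronger inhibitor in this assay. Its gap to compound 1 lies beyond the usual scatter of repeated measurements. The two compounds differ in more than one place, so that gap cannot be tied to any single change.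

The next compound, compound 3 `Cc1c2c(n3c1CCN(C)C[C@@H](C)[C@H](C)Nc1cc-3ccc1C(N)=O)CC(C)(C)CC2=O`, is compound 2 with one alteration: methyl in place of hydrogen on an amine nitrogen in a ring. Among the measured compounds shown here, no measured pair shows this change on its own, so any forecast here is uncertain. With compound 2 at 24 nM as the starting point, a single added methyl is expected to bring a modest move toward a higher number, possibly no larger than the scatter. The estimated change is a 1.7-fold higher number from compound 2 to compound 3 (0.22 log units; within the scatter). For compound 3 the estimated value is 40 nM, with an expected range from 12 nM to 130 nM.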

Compound 3, half-maximal inhibitory concentration: 27 nM
The estimate for compound 3 lay 1.5-fold (0.17 log units) above the measured number; the range from low to high includes it.
By their numbers in this assay, from the lowest: compounds 2 and 3 (each within the scatter of the next); then compound 1.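

Among the compounds shown here, until now, no pair of compounds isolated a change at the amine nitrogen in the ring. In this assay, the new pair gives a 1.1-fold higher number from compound 2 to compound 3 (0.05 log units; within the scatter), so the two compounds cannot be told apart, and the nitrogen can carry either a hydrogen or a methyl with the antiproliferative number staying in the same range. The hydrogen on this nitrogen is therefore not needed to reach that range, although no measurement available here gives any explanation for this result.

A single methyl is the smallest carbon group that could be placed here, so the compounds shown leave open whether an ethyl group, a benzyl group or a longer chain on this nitrogen would give a similar number. They also leave open whether the match between compound 2 and compound 3 extends beyond this assay to other cell lines.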